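Swapping a pyridine for a chlorinated phenol on a hydrazone

This account rests on a few compounds, and the source may have more. Where it says the series, first, only, none or still open, it means among the compounds named here.

In a functional assay on PC-3 cells (Homo sapiens) for inhibition (a lower number here means a stronger inhibitor, a higher number a weaker inhibitor), compound 3 `Cc1c(C(=O)N/N=C\c2ccncc2)oc2cccc(O)c12` gives only a limit, >= 40000 nM. Compound 1 `Cc1c(C(=O)N/N=C\c2cc(O)ccc2O)oc2cccc(O)c12` gives 95500 nM in this assay. Compound 2 `Cc1c(C(=O)N/N=C\c2ccccn2)oc2cccc(O)c12` also gives only a limit, >= 40000 nM. Compound 4 `Cc1c(C(=O)N/N=C\c2cc(Cl)ccc2O)oc2cccc(O)c12` is not yet measured; it differs from compound 3 by 5-chloro-2-hydroxyphenyl in place of pyridin-4-yl on a carbon with a double bond to nitrogen. The steps a step that the limit leaves unreadable from compound 1 to compound 3 and a step that the limit leaves unreadable from compound 1 to compound 2 and a step that the two limits leave unreadable from compound 2 to compound 3 cannot be sized, as two of three values sit at the limit (the limit of >= 40000 nM in this assay, at which 2 of the 3 values shown sit). Compound 4 is therefore expected to remain weak, with a step that the limit leaves unreadable from compound 3 to compound 4 that is only an estimate. Compound 4 is expected to give about 60000 nM in this assay, with a range from 20000 nM to 200000 nM.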

Compound 4, half-maximal inhibitory concentration: 3120 nM
The estimate for compound 4 lay 19-fold (1.28 log units) above the measured number; the measured number lies below the stated range.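

In this assay, the group on the carbon with a double bond to nitrogen clearly matters: 5-chloro-2-hydroxyphenyl gives an at least 12-fold lower number from compound 3 to compound 4 (1.10 log units; beyond the scatter) and an at least 12-fold lower number from compound 2 to compound 4 (1.10 log units; beyond the scatter). The ring substituent matters too, as chloro in place of hydroxy on an aromatic carbon gives a 31-fold lower number from compound 1 to compound 4 (1.49 log units; beyond the scatter), so a hydroxylated benzene ring alone does not bring compound 1 to the level of compound 4. The steps among compounds 1, 2 and 3 cannot be read, because of the assay limit: the limit of >= 40000 nM in this assay, at which 2 of the 4 values shown sit.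

Going by these compounds, whether bromo or methoxy in place of chloro would serve as well remains open.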